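This account rests on a few compounds, and the source may have more. Where it says the series, first, only, none or still open, it means among the compounds named here.

In a functional assay on A549 cells (Homo sapiens) for inhibition, read by sulforhodamine B assay (a higher number here means a weaker inhibitor of growth, a lower number a stronger inhibitor of growth), compound 1 (`COc1ccc(-c2ccc(-c3ccc(-c4nc5ccccc5[nH]4)cc3)cc2)cc1`) gives 38100 nM, compound 2 (`Oc1cccc2[nH]c(-c3ccc(-c4ccc(-c5ccc(F)cc5)cc4)cc3)nc12`) gives 170 nM, and compound 3 (`Oc1cccc2[nH]c(-c3ccc(-c4ccc(-c5ccc(C(F)(F)F)cc5)cc4)cc3)nc12`) gives 3610 nM, the second highest of the three numbers. Compound 4 (`COc1ccc(-c2ccc(-c3ccc(-c4nc5c(O)cccc5[nH]4)cc3)cc2)cc1`) comes from compound 3 by one change, methoxy in place of trifluoromethyl on an aromatic carbon. Among the measured compounds shown here, only one measured step touches this spot: a 21-fold higher number from compound 2 to compound 3 (1.33 log units; beyond the scatter), a large rise on swapping fluoro for trifluoromethyl. Compound 1 also ends in 4-methoxyphenyl, but it differs elsewhere, so it does not isolate this change. Leaving trifluoromethyl should therefore lower the number, and the expected step is a 6.0-fold lower number from compound 3 to compound 4 (0.78 log units; beyond the scatter), beyond the scatter. For compound 4 the estimated value is 600 nM, with an expected range of 120 nM to 3000 nM.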

Compound 4, concentration for 50% growth inhibition: 7690 nM
Compound 4: middle estimate off by 13-fold (1.11 log units), on the low side; measured number outside the range, above it.
By their numbers in this assay, from the lowest: compound 2; then compound 3; then compound 4; then compound 1.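

In this assay, the step of a 2.1-fold higher number from compound 3 to compound 4 (0.33 log units; beyond the scatter) shows that removing trifluoromethyl from this position does not by itself bring the number down. With a 45-fold higher number from compound 2 to compound 4 (1.66 log units; beyond the scatter) as well, fluoro keeps the lowest number of the three end groups, and methoxy has the highest. Separately, a 5.0-fold lower number from compound 1 to compound 4 (0.69 log units; beyond the scatter) shows that hydroxy on the core helps while 4-methoxyphenyl stays in place. Nothing available explains this order. Still open, as far as these compounds go, is where chloro or an amine at this position would fall, and whether hydroxy gives a similar step with other end groups.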